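Removing the Trifluoromethyl from Compound 3

The source may report more compounds than this note shows. Statements on the series, on what has been measured and on what is new or still open speak of the compounds shown alone.

Compound 1 `FC(F)(F)c1ccc(Nc2ncnc3sc(Nc4c(Cl)cccc4Cl)nc23)cc1` gives 3 nM in a functional assay on HEK293 cells for antagonist activity at transient receptor potential cation channel subfamily V member 1 (Rattus norvegicus), read by calcium flux (a lower number here means a stronger inhibitor, a higher number a weaker inhibitor), and holds the lowest number shown. Compound 2 `FC(F)(F)c1ccc(Nc2cccc3sc(Nc4c(Cl)cccc4Cl)nc23)cc1` reaches only a limit of the assay, > 5000 nM, in this assay. Compound 3 `FC(F)(F)c1cccc(Nc2ncnc3sc(Nc4c(Cl)cccc4Cl)nc23)c1` gives 192 nM in this assay, the highest of the two numbers shown; its nearest neighbour is compound 1, whose number sits lower by a gap that lies well beyond the scatter, so the position of the trifluoromethyl on the outer ring alone separates the two.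

Compound 4 `Clc1cccc(Cl)c1Nc1nc2c(Nc3ccccc3)ncnc2s1` has not been measured. It differs from compound 3 by hydrogen in place of trifluoromethyl on an aromatic carbon. No pair of measured compounds makes this change, and every compound with a number shown still carries the trifluoromethyl, so nothing measured says what its loss does. Since compound 3 already gives 192 nM with the group in its weaker placement, the step from compound 3 to compound 4 is expected to lead further toward a weaker inhibitor, by a 4.7-fold higher number from compound 3 to compound 4 (0.67 log units; beyond the scatter), beyond the scatter. Compound 4 is therefore estimated at 900 nM in this assay, between 200 nM and 4000 nM.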

Compound 4, half-maximal inhibitory concentration: 170 nM
The estimate for compound 4 lay 5.3-fold (0.72 log units) above the measured number; measured number outside the range, below it.
By their numbers in this assay, from the lowest: compound 1; then compounds 4 and 3 (each within the scatter of the next). At a limit, above all of these: compound 2.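

In this assay, hydrogen in place of trifluoromethyl on an aromatic carbon can now be read directly, and from the placement in compound 3 the exchange leaves the number unchanged within the scatter: a 1.1-fold lower number from compound 3 to compound 4 (0.05 log units; within the scatter) is all that separates them. The same exchange from the other placement is a large step, a 57-fold higher number from compound 1 to compound 4 (1.75 log units; beyond the scatter), so the trifluoromethyl matters greatly in the placement it holds in compound 1, while in the placement it holds in compound 3 it shows no gain over hydrogen. Nothing shown here gives a measured reason for this contrast between the two placements.

As far as these compounds go, whether a chlorine, a methoxy group or an amine could match the trifluoromethyl in the placement of compound 1 remains open. Also open, from the compounds shown here alone, is whether a nitrile in the placement of compound 3 would read any differently from hydrogen.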